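Pyrazolyl in Place of Azetidinylpyridyl on a Shared Core

A few compounds are considered here, and "the series" means these few. Any claim that something is new, unique, unknown or untested is made for them only; others in the source may bear on it.

Measured so far:
compound 1 `O=C(O)Cc1sc(C(c2ccc(F)cc2)c2ccc(F)cc2)nc1-c1ccnc(N2CCC2)c1`: 660 nM
compound 2 `COc1ccc(OC)c(-c2nc(C(c3ccccc3)c3ccccc3)sc2CC(=O)O)c1`: a limit, > 105 nM
compound 3 `O=C(O)Cc1sc(C(c2ccc(F)cc2)c2ccc(F)cc2)nc1-c1cccc(F)c1`: 1.4 nM

In an in vitro assay on HEK385-7 cells for displacement of a labelled ligand from prostaglandin D2 receptor 2 (Homo sapiens) (a higher number here means a weaker inhibitor, a lower number a stronger inhibitor), compound 1 gives 660 nM, the highest of the two numbers shown. For compound 2 the assay reports only a limit, > 105 nM. Compound 3 gives 1.4 nM; the step of a 470-fold lower number from compound 1 to compound 3 (2.67 log units; beyond the scatter) is large. Compound 4 `O=C(O)Cc1sc(C(c2ccc(F)cc2)c2ccc(F)cc2)nc1-c1cn[nH]c1` carries 1H-pyrazol-4-yl in place of 2-(azetidin-1-yl)pyridin-4-yl on an aromatic carbon. Among the compounds with values here, only the step from compound 1 to compound 3 bears on this change: there 3-fluorophenyl replaced the same 2-(azetidin-1-yl)pyridin-4-yl and the number fell steeply. The 1H-pyrazol-4-yl is likewise a single small aromatic ring, though not 3-fluorophenyl, and a lower number is expected for compound 4, with a step smaller than that seen for compound 3. Compound 4 is estimated at 30 nM in this assay, between 3 nM and 300 nM, which is expected to be a step of a 22-fold lower number from compound 1 to compound 4 (1.34 log units; beyond the scatter).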

Compound 4, half-maximal inhibitory concentration: 16 nM
Estimate against measurement, compound 4: 1.9-fold (0.27 log units) above; low and high end bracket the measured number.
By their numbers in this assay, from the lowest: compound 3; then compound 4; then compound 1.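

In this assay, the position that carries 2-(azetidin-1-yl)pyridin-4-yl in compound 1 now has a second replacement that lowers the number, with a 41-fold lower number from compound 1 to compound 4 (1.62 log units; beyond the scatter), so the fall does not depend on 3-fluorophenyl alone. The choice of the entering ring still matters, with an 11-fold higher number from compound 3 to compound 4 (1.06 log units; beyond the scatter). Nothing at hand accounts for either step.

As far as these compounds go, it remains open whether the high number of compound 1 comes from the azetidine or from the pyridine ring that bears it. From the compounds shown here alone, how a plain pyridin-4-yl or a 1-methylpyrazol-4-yl would stand at this position also remains open.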